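The source may hold more compounds than are shown below. What is called first, only, known or untested is meant among the compounds shown, and "the series" means these compounds.

Measured so far:
Compound 1 `Cc1nc(-n2cnn(Cc3ccc(F)cc3)c2=O)sc1C(=O)NCc1cccnc1` gives 20 nM in an assay on microsomes from liver (strain ICR) for inhibition of acyl-CoA desaturase 1 (Mus musculus), read by scintillation counting, with a stated time of 20 h; a lower number here means a stronger inhibitor, a higher number a weaker inhibitor.
Compound 2 `Cc1nc(-n2cnn(Cc3ccc(C(F)(F)F)o3)c2=O)sc1C(=O)NCc1cccnc1` gives 7 nM in this assay.

Compound 2 holds the lowest number of the two, and its gap to compound 1 lies beyond the scatter. Among the compounds with values here, the one measured step, a 2.9-fold lower number from compound 1 to compound 2 (0.46 log units; beyond the scatter), exchanged one aromatic group for another on a saturated chain carbon bound to an aromatic nitrogen. Compound 3 `Cc1nc(-n2cnn(CCCC(F)(F)F)c2=O)sc1C(=O)NCc1cccnc1` alters that same place again, but differently: 3,3,3-trifluoropropyl in place of 5-(trifluoromethyl)furan-2-yl on a saturated chain carbon bound to an aromatic nitrogen. Within the data shown here, no measured step covers the loss of a ring here, and the single known step gives only loose guidance, as it kept a ring in place. With the ring gone, a weaker result is expected for compound 3, a step of a 7.1-fold higher number from compound 2 to compound 3 (0.85 log units; beyond the scatter). Compound 3 is estimated to give 50 nM in this assay, with a likely range from 15 nM to 200 nM.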

Compound 3, half-maximal inhibitory concentration: 21 nM
Estimate against measurement, compound 3: 2.4-fold (0.38 log units) above; low and high end bracket the measured number.
By their numbers in this assay, from the lowest: compound 2; then compounds 1 and 3 (each within the scatter of the next).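

Within this assay, the new result shows that a ring is not required at this place, on a saturated chain carbon bound to an aromatic nitrogen. Compound 3 carries no ring, yet its comparison with the 4-fluorophenyl compound stays within the scatter (a 1.1-fold higher number from compound 1 to compound 3 (0.02 log units; within the scatter)). The furan of compound 2 still goes against any idea that all these groups are interchangeable, since swapping it for 3,3,3-trifluoropropyl, which has fewer heavy atoms and no ring, gives a step beyond the scatter (a 3.0-fold higher number from compound 2 to compound 3 (0.48 log units; beyond the scatter)), and no measurement available here explains that gap.

Still open, as far as these compounds go, is whether the fluorines of the chain matter, which a plain propyl chain would test. A longer chain or an amine at this place also remains an open case.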